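Inverting the Single Stereocentre of Compound 1

The source may report more compounds than this note shows. Statements on the series, on what has been measured and on what is new or still open speak of the compounds shown alone.

Measured in a functional assay on B16-F1 cells (Mus musculus) for cytotoxicity, read by sulforhodamine B assay, with a stated time of 48 h (a lower number here means a stronger inhibitor, a higher number a weaker inhibitor), so far:
compound 1 `COc1cc(NC(=O)[C@H]2CSC(c3ccccc3)=N2)cc(OC)c1OC` gives 30400 nM as its result
compound 2 `COc1cc(NC(=O)[C@@H]2CSC(c3ccccc3)N2)cc(OC)c1OC` gives > 100000 nM as its result

Within the data shown here, compound 1 holds the only actual number in this small set, and it sits in the high micromolar range. For compound 2 the reading of > 100000 nM is a limit of the assay and not a number.

The open question is compound 3 `COc1cc(NC(=O)[C@@H]2CSC(c3ccccc3)=N2)cc(OC)c1OC` and how it behaves in this assay when set against compound 1. The structural difference is the two compounds have the same atoms and bonds and differ only in configuration as drawn: 1 of 1 stereo elements differ; a stereocentre at a saturated ring carbon is drawn S in compound 1 and R in compound 3 and nothing else: a stereocentre at a saturated ring carbon is drawn S in compound 1 and R in compound 3. Among the measured compounds shown here, no measured pair in the set isolates a change of configuration, so the expectation has only compound 1 at 30400 nM as its anchor. The expected outcome is a 1.0-fold lower number from compound 1 to compound 3 (0.01 log units; within the scatter) as the estimated change, with no step beyond the usual scatter and no favoured direction. For compound 3 the estimate is 30000 nM as a central value, with an expected range from 11000 nM to 85000 nM in this assay.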

Compound 3, half-maximal inhibitory concentration: 38300 nM
The estimate for compound 3 lay 1.3-fold (0.11 log units) below the measured number; the range from low to high includes it.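

Inverting the stereocentre at the saturated ring carbon gives, in this assay, a 1.3-fold higher number from compound 1 to compound 3 (0.10 log units; within the scatter). Among these compounds, this is the first measured pair in the set that isolates a change of configuration, and at this ring carbon the change from S to R as drawn leaves the result within the usual scatter, so neither form can be ranked over the other. The comparison rests on that single change alone: the fact that compounds 1 and 3 differ only in the configuration as drawn.

Among the compounds shown here, compound 2 gives > 100000 nM, which is a limit of the assay and not a number, so no step involving compound 2 can be read. On these data alone, it also remains open whether configuration at this ring carbon would still count for so little in this assay if the core of compound 1 carried an added group such as an amine or a carboxylic acid, since both compounds of the measured pair share the same atoms and bonds.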